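Swapping Chloro for Methoxy on the Fused Ring

The compounds below may be only part of what the source reports. "The series", "measured", "known", "first", "only" and "open" are said of these compounds alone.

Among the compounds with values here, compound 2 `O=C(Nc1nc2ccc(Cl)cc2s1)c1cn(-c2ccccc2)nc1-c1ccc(Cl)cc1` is the only compound here with a measured number: in a functional assay on HT-29 cells (Homo sapiens) for cytotoxicity, read by MTT assay, with a stated time of 72 h (on this read-out higher numbers stand for weaker inhibition and lower numbers for stronger inhibition), compound 2 gives 4550 nM. Compound 1 `COc1ccc2nc(NC(=O)c3cn(-c4ccccc4)nc3-c3ccccc3)sc2c1` reached only a limit of the assay, > 50000 nM, not a number. Compound 3 `COc1ccc2nc(NC(=O)c3cn(-c4ccccc4)nc3-c3ccc(Cl)cc3)sc2c1` differs from compound 2 by methoxy in place of chloro on an aromatic carbon. Within the data shown here, no measured pair isolates this change, but compound 1, which also carries the methoxy there, sits at the limit (the limit of > 50000 nM in this assay, at which 1 of the 2 values shown sits). The step from compound 2 to compound 3 is expected to weaken inhibition beyond the scatter, a 3.3-fold higher number from compound 2 to compound 3 (0.52 log units; beyond the scatter). Compound 3 is estimated at 15000 nM, within a range from 4000 nM to 50000 nM.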

Compound 3, half-maximal inhibitory concentration: 18600 nM
Estimate against measurement, compound 3: 1.2-fold (0.09 log units) below; the range from low to high includes it.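

A measured pair now isolates the swap on the fused ring, with methoxy in place of chloro on the same aromatic carbon: a 4.1-fold higher number from compound 2 to compound 3 (0.61 log units; beyond the scatter). Within the data shown here, compound 3 also gives a first reading of a second change, chloro in place of hydrogen on an aromatic carbon elsewhere in the molecule, and this raises inhibition: an at least 2.6-fold lower number from compound 1 to compound 3 (0.42 log units; beyond the scatter). That step has only a bound, as the value of compound 1 is a limit, not a number: the limit of > 50000 nM in this assay, at which 1 of the 3 values shown sits.

Still open, on these data alone, is how an amine or a carboxylic acid would behave on the fused ring. The compounds shown also leave open whether a longer chain in place of methoxy would keep the same trend.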